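Replacing the hydrazide of compound 1 with a piperidine amide

The source may hold more compounds than are shown below. What is called first, only, known or untested is meant among the compounds shown, and "the series" means these compounds.

Compound 1 `NNC(=O)Cn1nc(N)c2c(C(F)(F)F)cc(-c3ccccc3)nc21` gives 52400 nM in a functional assay on DU-145 cells (Homo sapiens) for cytotoxicity, read by MTT assay, with a stated time of 24 h (a lower number here means a stronger inhibitor, a higher number a weaker inhibitor), and stands as the higher of the two numbers shown, though the step of a 1.3-fold lower number from compound 1 to compound 2 (0.13 log units; within the scatter) is within the scatter; compound 2 `NCCNC(=O)Cn1nc(N)c2c(C(F)(F)F)cc(-c3ccccc3)nc21` gives 38900 nM. Compound 3 `Nc1nn(CC(=O)N2CCCCC2)c2nc(-c3ccccc3)cc(C(F)(F)F)c12` differs from compound 1 by piperidin-1-yl in place of aminoamino on a carbonyl carbon. Among the compounds with values here, the single measured step bears on this only loosely, since it kept a free amine on the amide nitrogen while compound 3 has none. With no step beyond the scatter to lean on, compound 3 is expected to sit near compound 1, with a 1.3-fold lower number from compound 1 to compound 3 (0.12 log units; within the scatter) a small step. The value of compound 3 is estimated at 40000 nM, between 15000 nM and 110000 nM.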

Compound 3, half-maximal inhibitory concentration: 3200 nM
The estimate for compound 3 lay 13-fold (1.10 log units) above the measured number; the whole stated range lies above it.
By their numbers in this assay, from the lowest: compound 3; then compounds 2 and 1 (each within the scatter of the next).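

In this assay, the group on this carbonyl carbon turns out to matter far more than the earlier pair showed: a 16-fold lower number from compound 1 to compound 3 (1.21 log units; beyond the scatter) and a 12-fold lower number from compound 2 to compound 3 (1.08 log units; beyond the scatter), both large, whereas swapping amino for 2-aminoethyl on the amide nitrogen stayed within the scatter. Piperidin-1-yl, the only one of these groups with a six-membered non-aromatic ring, gives the lowest number of the three. Nothing measured here accounts for the size of this step. As far as these compounds go, whether the drop needs that ring stays open: a pyrrolidine, a morpholine or an open-chain dimethylamino group on the same carbonyl carbon would separate these possibilities.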